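A few compounds are considered here, and "the series" means these few. Any claim that something is new, unique, unknown or untested is made for them only; others in the source may bear on it.

Compound 1, `COc1cccc(NC(=O)c2nnn(CC3CCNCC3)c2N)c1`, gives < 0.5 mL.min-1.g-1 in an ADME assay on microsomes from liver (Mus musculus, strain CD1) for metabolic stability, read by HPLC, using NADPH, with a stated time of 30 min; on this read-out higher numbers stand for fast clearance and lower numbers for slow clearance. That reading for compound 1 is a limit of the assay rather than a number.
Compound 2, `COc1cccc(NC(=O)c2nnn(CC3CCN(C(C)=O)CC3)c2N)c1`, gives 0.7 mL.min-1.g-1 in this assay.
Compound 3, `COc1cccc(NC(=O)c2nnn(Cc3ccncc3)c2N)c1`, gives 0.7 mL.min-1.g-1 in this assay.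

Compound 3 stands level with compound 2 at the digits shown, as the step of no change at the digits printed from compound 2 to compound 3 (within the scatter) records; the only other value is the limit of compound 1 (the limit of < 0.5 mL.min-1.g-1 in this assay, at which 1 of the 3 values shown sits), so from compound 1 the steps of an at least 1.4-fold higher number from compound 1 to compound 2 (0.14 log units; that floor lies within the scatter) and an at least 1.4-fold higher number from compound 1 to compound 3 (0.14 log units; that floor lies within the scatter) can only be given as floors. Among the compounds with values here, all three values therefore sit close together, and no compound can be called clearly faster or slower cleared than another.

Compound 4 is `COc1cccc(NC(=O)c2nnn(Cc3ccc(C4CC4)cc3)c2N)c1`. It differs from compound 3 by 4-cyclopropylphenyl in place of pyridin-4-yl on a saturated chain carbon bound to an aromatic nitrogen. Within the data shown here, the two measured steps at that same place, ending in compound 3, swapped between pyridin-4-yl, piperidin-4-yl and 1-acetylpiperidin-4-yl, and the one with two numbers, no change at the digits printed from compound 2 to compound 3 (within the scatter), showed no change. None of them brought in a ring of carbon only or a three-membered ring, so they bear on the change only loosely. The step to compound 4 is expected to be a 2.9-fold higher number from compound 3 to compound 4 (0.46 log units; beyond the scatter) in this assay, toward faster clearance but with wide uncertainty. Compound 4 is estimated at 2 mL.min-1.g-1, between 0.7 mL.min-1.g-1 and 6 mL.min-1.g-1.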

Compound 4, intrinsic clearance in microsomes: 4.9 mL.min-1.g-1
Compound 4: the middle estimate sits 2.5-fold (0.39 log units) below what was measured, and the stated range covers the measured number.
By their numbers in this assay, from the lowest: compounds 2 and 3 (each within the scatter of the next); then compound 4. At a limit, below all of these: compound 1.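

At this place, on a saturated chain carbon bound to an aromatic nitrogen, the earlier swaps among saturated and pyridine rings gave no step shown to lie beyond the scatter, whereas 4-cyclopropylphenyl does so in this assay, with a 7.0-fold higher number from compound 3 to compound 4 (0.85 log units; beyond the scatter) and a 7.0-fold higher number from compound 2 to compound 4 (0.85 log units; beyond the scatter). Compared with the free piperidine, the change gives an at least 9.8-fold higher number from compound 1 to compound 4 (0.99 log units; beyond the scatter), so all three steps to compound 4 point toward faster clearance, and the group at this place is now seen to be able to shift this read-out clearly. That last step can be stated only as a floor, since the reading for compound 1 is a limit of the assay: the limit of < 0.5 mL.min-1.g-1 in this assay, at which 1 of the 4 values shown sits.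

In compound 4, a ring of carbon replaces the pyridine ring and a cyclopropyl group enters in a single change, so the compounds shown cannot say which of the two goes with the higher clearance. A plain phenyl at this place would separate the two, and a 4-methylphenyl or a 4-isopropylphenyl would show whether the three-membered ring itself matters or any small carbon group gives the same reading.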